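This account rests on a few compounds, and the source may have more. Where it says the series, first, only, none or still open, it means among the compounds named here.

Measured so far:
compound 1, `CCOC(=O)C(=O)C(CC)NC(=O)C(CC(C)C)NC(=O)CCc1ccccc1`, 1200 nM
compound 2, `CCOC(=O)C(=O)C(CC)NC(=O)C(CC(C)C)NC(=O)CCCCc1ccccc1`, 1900 nM

Both compounds carry the same core and differ only in the chain on the terminal carbonyl. In an assay on isolated protein (Oryctolagus cuniculus) for inhibition of Calpain-2 catalytic subunit (Homo sapiens), at pH 8.0 (a higher number here means a weaker inhibitor, a lower number a stronger inhibitor), compound 1 gives 1200 nM and compound 2 gives 1900 nM; the step of a 1.6-fold higher number from compound 1 to compound 2 (0.20 log units; within the scatter) is within the scatter, so the two values cannot be ordered. Compound 2 therefore has the higher of the two numbers, but only by a margin that repeated measurement would blur.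

Compound 3, `CCOC(=O)C(=O)C(CC)NC(=O)C(CC(C)C)NC(=O)OCC(C)C`, has not yet been measured. Its difference from compound 2 is isobutoxy in place of 4-phenylbutyl on a carbonyl carbon. Going by the values given here, no measured step covers this kind of exchange: the only step available, a 1.6-fold higher number from compound 1 to compound 2 (0.20 log units; within the scatter), alters the chain length at that carbonyl and stays within the scatter. The step to compound 3 removes the aromatic ring altogether and puts an oxygen into the chain, which is a larger change than anything measured here, so the expectation rests on weak ground. Given that the one known step at this position was flat, no shift beyond the scatter is expected, with a wide range to cover the unmeasured kind of change. Compound 3 is expected to give 1500 nM, between 500 nM and 4500 nM, which would be a step of a 1.3-fold lower number from compound 2 to compound 3 (0.10 log units; within the scatter).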

Compound 3, inhibition constant: 17000 nM
Compound 3: the middle estimate sits 11-fold (1.05 log units) below what was measured, and the stated range ends below it.
By their numbers in this assay, from the lowest: compounds 1 and 2 (each within the scatter of the next); then compound 3.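

In this assay, the group on this carbonyl carbon, whose other neighbours are amide-type nitrogen, turns out to matter: isobutoxy in place of 4-phenylbutyl gives an 8.9-fold higher number from compound 2 to compound 3 (0.95 log units; beyond the scatter), and isobutoxy in place of phenethyl gives a 14-fold higher number from compound 1 to compound 3 (1.15 log units; beyond the scatter), whereas the earlier exchange between the two phenyl-bearing chains gave only a 1.6-fold higher number from compound 1 to compound 2 (0.20 log units; within the scatter). The position therefore tolerates that exchange between phenyl-bearing chains but not this replacement, with both compound 1 and compound 2 showing lower numbers than compound 3. The replacement removes the six-membered aromatic ring, brings in an oxygen and shortens the group all at once, and no measurement here bears on why the number rises or separates these parts of the change.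

The compounds shown leave open whether the loss follows the ring or the oxygen: benzyloxy would keep both the ring and the oxygen, while an all-carbon isopentyl group would have neither. A longer chain ending in a cyclohexyl ring would further test whether an aromatic ring is needed at all, or whether a ring of any kind serves at this carbonyl.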